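This account rests on a few compounds, and the source may have more. Where it says the series, first, only, none or still open, it means among the compounds named here.

Three compounds were tested in a functional assay on BGC-823 cells (Homo sapiens) for cytotoxicity, read by MTT assay, with a stated time of 24 h; a lower number here means a stronger inhibitor, a higher number a weaker inhibitor: compound 1 (`CC(C)C1=C[C@]2(O)CC[C@H]3[C@]4(C)CCC[C@]3(C(=O)OC4)C2=CC1=O`), compound 2 (`CC(C)c1cc2c(cc1O)[C@]13CCC[C@]4(C)CO[C@@H]1O[C@H]2C[C@@H]43`) and compound 3 (`CC(C)c1cc2c(cc1O)[C@]13CCC[C@](C)(CO[C@@H]1O)[C@@H]3CC2`). Compound 1 gives > 10000 nM, which is a limit of the assay and not a number. Compound 2 gives > 10000 nM, again a limit. Compound 3 gives > 10000 nM, also a limit. Compound 3 therefore has no exact value and stands with the other two at the limit of > 10000 nM in this assay, at which 3 of the 3 values shown sit.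

Compound 4 (`CO[C@H]1OC[C@@]2(C)CCC[C@@]13c1cc(O)c(C(C)C)cc1CC[C@@H]23`) differs from compound 3 in one place: methyl in place of hydrogen on an oxygen on a saturated carbon. This is methyl in place of hydrogen on an oxygen on a saturated carbon, or hydroxy to methoxy. Among the measured compounds shown here, no step between measured compounds gives a direct guide to the size of this change in this assay. The expectation rests on compound 3, whose > 10000 nM is a limit, and on its two companions, which offer no sign of activity. No step beyond the scatter is expected, and compound 4 will most likely also be reported only as a limit. For compound 4 the estimated value is 20000 nM, with an expected range of 7000 nM to 50000 nM. The expected change is a step that the limit leaves unreadable from compound 3 to compound 4.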

Compound 4, half-maximal inhibitory concentration: > 10000 nM
Compound 4: a limit, no number (the forecaster's own chance of this, stated with the estimate: 75%); the middle value does not contradict the limit.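

In this assay compound 4 gives > 10000 nM, which is a limit and not a number. Compound 3 also stands only at a limit, and the step from it to compound 4 cannot be read. The compounds shown leave open what exact value any of them has, and whether hydroxy to methoxy changes it at all: the limit of > 10000 nM in this assay, at which 4 of the 4 values shown sit.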